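This account rests on a few compounds, and the source may have more. Where it says the series, first, only, none or still open, it means among the compounds named here.

Working notes on the series. The shared core of compound 1 `O=C(CSc1nc2ccccc2[nH]1)c1ccc(Br)cc1` carries a bromo group; compound 2 `O=C(CSc1nc2ccccc2[nH]1)c1ccc(O)cc1` carries a hydroxy group in its place, and compound 3 `COc1ccc(C(=O)CSc2nc3ccccc3[nH]2)cc1OC` carries two methoxy groups on the same ring. In a functional assay on HT-29 cells (Homo sapiens) for inhibition, read by flow cytometry, tested at 10 uM (on this read-out higher numbers stand for more inhibition at the one concentration tested (going by the name of the read-out) and lower numbers for less inhibition), compound 1 is reported as "not active" (no number reported). In this assay compound 2 is likewise reported as "not active" (no number reported), so no number stands for it; compound 1 is the one further entry without a number. In this assay, among the measured compounds shown here, compound 3 gives 52.6%, the only number in the set so far. Compound 2 therefore stands at the bottom of what is known, with no measured number of its own.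

Compound 4 `O=C(CSc1nc2ccccc2[nH]1)c1ccc([N+](=O)[O-])cc1` is the next member to be measured. It differs from compound 2 by nitro in place of hydroxy on an aromatic carbon. For the measured compounds named here, no step between two measured compounds exists, so no measured size of change can be transferred to this pair; the expectation for this assay rests only on compound 2 being reported without a number and compound 3 giving a moderate reading. A step upward from compound 2 that is small or within the scatter is expected, with the direction uncertain. For compound 4 in this assay an inhibition of 18% is estimated, expected to fall between 0% and 48%.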

Compound 4, a percentage reported as inhibition, at one concentration (the size of the read-out at that concentration, not a potency): "not active" (no number reported)
No number was reported for compound 4; there is nothing to compare the estimate with.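

In this assay compound 2 and compound 4 are both reported without a number, so no step can be read between them. The compounds shown leave open whether any single group change on this ring shifts the reading by a measurable amount, since compound 3 alone carries a number. No available evidence bears on this result.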